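The source may hold more compounds than are shown below. What is called first, only, known or untested is meant among the compounds shown, and "the series" means these compounds.

Three compounds sharing the core of compound 2 `NS(=O)(=O)c1ccc(Nc2nncc3ccccc23)cc1` have been measured in a functional assay on COLO 205 cells (Homo sapiens) for antiproliferative activity, read by sulforhodamine B assay, with a stated time of 72 h; on this read-out higher numbers stand for weaker inhibition and lower numbers for stronger inhibition. Compound 2 gives 23 nM, the lowest of the three numbers, though its gap to compound 1 is within the scatter. Compound 1 `Cc1cc(NS(=O)(=O)c2ccc(Nc3nncc4ccccc34)cc2)no1`, which carries a 5-methyl-1,2-oxazol-3-yl on the sulfonamide nitrogen, gives 43 nM, and compound 3 `O=S(=O)(Nc1nccs1)c1ccc(Nc2nncc3ccccc23)cc1`, with a 1,3-thiazol-2-yl there, gives 56 nM. The step of a 1.9-fold lower number from compound 1 to compound 2 (0.27 log units; within the scatter) lies within the scatter, whereas a 2.4-fold higher number from compound 2 to compound 3 (0.39 log units; beyond the scatter) counts as a modest change, and a 1.3-fold higher number from compound 1 to compound 3 (0.11 log units; within the scatter) is again within the scatter. Compound 4 `N#Cc1ccc(Nc2nncc3ccccc23)cc1` departs from compound 2 in a different way: cyano in place of sulfamoyl on an aromatic carbon. Among the compounds with values here, none of the measured steps touches the sulfamoyl itself; they only vary what sits on its nitrogen, and those variations move this assay by modest amounts at most. The measured steps give no direct guide to removing the sulfamoyl altogether, so the expectation for compound 4 rests on the modest spread seen so far and is a small step of a 2.2-fold higher number from compound 2 to compound 4 (0.34 log units; beyond the scatter). Compound 4 is accordingly estimated at 50 nM, with a range from 15 nM to 200 nM.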

Compound 4, half-maximal inhibitory concentration: 2.5 nM
Compound 4: middle estimate off by 20-fold (1.30 log units), on the high side; the measured number lies below the stated range.
By their numbers in this assay, from the lowest: compound 4; then compounds 2, 1 and 3 (each within the scatter of the next, the first and the last beyond it).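

In this assay, exchanging the whole group on this aromatic carbon moves the number further than anything done on the sulfonamide nitrogen: cyano in place of sulfamoyl gives a 9.2-fold lower number from compound 2 to compound 4 (0.96 log units; beyond the scatter), while the largest earlier step was a 2.4-fold higher number from compound 2 to compound 3 (0.39 log units; beyond the scatter). Within the data shown here, the position, para to a large group, therefore responds more to what occupies it than the earlier steps suggested, and the sulfamoyl is not required for a low number on these cells. Nothing available here explains why the number falls so far.

The compounds shown leave open whether the low number is particular to cyano, or would also hold with a carboxylic acid, an amine or a plain hydrogen on this carbon. They also leave open whether the same step would appear on cell lines other than COLO 205.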